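The source may report more compounds than this note shows. Statements on the series, on what has been measured and on what is new or still open speak of the compounds shown alone.

Measured compounds and their values:
- Compound 1, `COc1ncnc2c1c(I)cn2[C@@H]1O[C@H](CO)[C@@H](O)[C@H]1O`, gives 91000 nM in an ADME assay on BJ cells (Homo sapiens), read by MTT assay, with a stated time of 72 h; a higher number here means a weaker inhibitor, a lower number a stronger inhibitor.
- Compound 2, `C#Cc1cn([C@@H]2O[C@H](CO)[C@@H](O)[C@H]2O)c2ncnc(OC)c12`, gives 98400 nM.
- Compound 3, `COc1ncnc2c1c(-c1ccco1)cn2[C@@H]1O[C@H](CO)[C@@H](O)[C@H]1O`, gives 430 nM.

Compound 2 has the highest of the three numbers. Its nearest neighbour is compound 1, which sits only a 1.1-fold higher number from compound 1 to compound 2 (0.03 log units; within the scatter) away, so the two cannot be told apart. Compound 3 lies far off: the step of a 230-fold lower number from compound 2 to compound 3 (2.36 log units; beyond the scatter) is large and well beyond the scatter, as is a 210-fold lower number from compound 1 to compound 3 (2.33 log units; beyond the scatter).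

Compound 4, `C#Cc1cn([C@@H]2O[C@H](CO)[C@@H](O)[C@H]2O)c2ncnc(N(C)C)c12`, keeps the ethynyl group of compound 2 and changes a different part of the shared core: dimethylamino in place of methoxy on an aromatic carbon.

None of the three measured steps touches this group. Every one of them swaps the substituent on the five-membered ring between iodo, ethynyl and furan-2-yl, while the methoxy group stays in place throughout. Among the compounds with values here, the data therefore say nothing directly about exchanging methoxy for dimethylamino, and the only anchor is the value of compound 2 itself.

Within the data shown here, with no step to lean on, the expectation for compound 4 is a change of about a 1.2-fold lower number from compound 2 to compound 4 (0.09 log units; within the scatter), that is, nothing clearly beyond the scatter. The estimated value for compound 4 is 80000 nM, with a wide range from 20000 nM to 300000 nM.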

Compound 4, half-maximal inhibitory concentration: 410 nM
Estimate against measurement, compound 4: 200-fold (2.29 log units) above; measured number outside the range, below it.
By their numbers in this assay, from the lowest: compounds 4 and 3 (each within the scatter of the next); then compounds 1 and 2 (each within the scatter of the next).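

In this assay, within the data shown here, dimethylamino in place of methoxy gives a 240-fold lower number from compound 2 to compound 4 (2.38 log units; beyond the scatter) and so shows that the group on the six-membered aromatic ring, held constant in all the earlier compounds, can by itself move this number by a large amount. Among these compounds, until now, the only large steps came from placing furan-2-yl on the five-membered ring, whereas this step keeps the ethynyl group and exchanges one small group for another, each counted with one hydrogen-bond acceptor and no donors. Nothing measured here explains why this exchange has so large an effect.

From the compounds shown here alone, it remains open whether dimethylamino has a similar effect when iodo or furan-2-yl sits on the five-membered ring, and therefore whether the changes at the two places add up or depend on each other. Going by these compounds, it is also open whether this effect is particular to dimethylamino or would extend to other groups on that aromatic carbon, such as a simple amine, methylamino, diethylamino with its longer chains, or a ring amine such as pyrrolidine.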